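Moving a chlorine on the aryl ring of an enone core

A few compounds are considered here, and "the series" means these few. Any claim that something is new, unique, unknown or untested is made for them only; others in the source may bear on it.

Compound 1 `O=C1/C(=C\c2cccc(Oc3ccccc3)c2)c2ccccc2N1c1c(Cl)cccc1Cl`: 24 ug/mL
Compound 2 `O=C1/C(=C\c2ccccc2Cl)c2ccccc2N1c1c(Cl)cccc1Cl`: > 100 ug/mL

Of the compounds shown here, two sharing one core have been measured in a functional assay on L132 cells (Homo sapiens) for cytotoxicity, read by MTT assay, with a stated time of 72 h; on this read-out lower numbers stand for an effect already at smaller amounts and higher numbers for an effect only at larger amounts of compound. Compound 1 gives 24 ug/mL in this assay. For compound 2 the result is only a limit of the assay, > 100 ug/mL, so compound 2 stands at the limit of > 100 ug/mL in this assay, at which 1 of the 2 values shown sits, and no number for it is known. The third compound, compound 3 `O=C1/C(=C\c2cccc(Cl)c2)c2ccccc2N1c1c(Cl)cccc1Cl`, has not been measured. It differs from compound 2 in one place: 3-chlorophenyl in place of 2-chlorophenyl on a double-bonded chain carbon bound to a double-bonded ring carbon.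

Among the compounds with values here, no step between two measured compounds is recorded, so the effect of this change rests only on the two values above. Compound 1 gives 24 ug/mL. Compound 2 sits at the limit. On that basis a move toward an effect at smaller amounts is expected for the step of an at least 1.8-fold lower number from compound 2 to compound 3 (0.25 log units; that floor lies within the scatter), though the result may again be only a limit. Compound 3 is therefore estimated at 55 ug/mL, with a range from 20 ug/mL to 120 ug/mL.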

Compound 3, concentration for half-maximal effect: 16 ug/mL
Estimate against measurement, compound 3: 3.4-fold (0.54 log units) above, and the stated range ends above it.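

In this assay, 3-chlorophenyl in place of 2-chlorophenyl on the double-bonded chain carbon gives an at least 6.2-fold lower number from compound 2 to compound 3 (0.79 log units; beyond the scatter), so with the same atoms joined differently, the place of the chlorine alone separates these two compounds. The size of this step is only a floor, since the result for compound 2 is a limit of the assay and not a number: the limit of > 100 ug/mL in this assay, at which 1 of the 3 values shown sits. Chloro in place of phenoxy on an aromatic carbon gives a 1.5-fold lower number from compound 1 to compound 3 (0.18 log units; within the scatter), so the two groups cannot be told apart at this place.

The compounds shown do not say whether an amine or a carboxylic acid on that same aromatic carbon would fit this picture. They also leave open why the place of the chlorine matters, and whether the same holds in cells other than these.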